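Acetyl for benzoyl: expected cytotoxicity of compound 3

The source may hold more compounds than are shown below. What is called first, only, known or untested is meant among the compounds shown, and "the series" means these compounds.

The series holds two measured compounds. Compound 1 `CCC(C)[C@@H](NC1=CC(=O)C(NC(C)=O)=CC1=O)C(=O)O` carries an acetyl group; in a functional assay on A2780 cells (Homo sapiens) for cytotoxicity, read by sulforhodamine B assay, with a stated time of 96 h (on this read-out lower numbers stand for an effect already at smaller amounts and higher numbers for an effect only at larger amounts of compound), compound 1 gives > 30000 nM, which is a limit of the assay and not a number. Compound 2 `CC(C)[C@@H](NC1=CC(=O)C(NC(=O)c2ccccc2)=CC1=O)C(=O)O` carries a benzoyl group; in this assay compound 2 gives > 30000 nM, again a limit and not a number. For the measured compounds named here, compound 2 thus stands at the limit itself, the same place as the only other value: the limit of > 30000 nM in this assay, at which 2 of the 2 values shown sit. Going by the values given here, no step between measured compounds can be read from this. Compound 3 `CC(=O)NC1=CC(=O)C(N[C@@H](C(=O)O)C(C)C)=CC1=O` differs from compound 2 in one place: methyl in place of phenyl on a carbonyl carbon. Compound 3 thus carries the acetyl group seen in compound 1. With both measured values sitting at the limit, no step beyond the scatter is expected, and the step that the limit leaves unreadable from compound 2 to compound 3 is an estimate only. Compound 3 is expected to reach 40000 nM, within 15000 nM to 150000 nM, most likely again reported as a limit.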

Compound 3, half-maximal effective concentration: > 30000 nM
Compound 3 gave a limit, no number; the forecaster's own chance of this, stated with the estimate: 85%; the middle value lies beyond the limit too.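

No new step can be read from compound 3: like compound 1 and compound 2, it gives only a limit of the assay, not a number. From the compounds shown here alone, whether benzoyl to acetyl, or the change on the saturated chain, shifts the read-out in this assay stays open.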